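The source may report more compounds than this note shows. Statements on the series, on what has been measured and on what is new or still open speak of the compounds shown alone.

Working notes on a short series of N-acyl threonine amides bearing a long alkyl amide chain, assessed in a functional assay on SiHa cells (Homo sapiens) for cytotoxicity, read by MTT assay, with a stated time of 48 h; on this read-out lower numbers stand for stronger inhibition and higher numbers for weaker inhibition.

Compound 1 `CCCCCCCCCCCCCCNC(=O)[C@@H](NC(=O)c1ccco1)[C@@H](C)O` carries a furan-2-yl on the carbonyl carbon and a tetradecyl chain; in this assay compound 1 gives 127000 nM. Compound 2 `CCCCCCCCCCCCCCNC(=O)[C@@H](NC(=O)c1cccs1)[C@@H](C)O` differs from compound 1 by thiophen-2-yl in place of furan-2-yl on a carbonyl carbon; in this assay compound 2 gives 63000 nM, so that a 2.0-fold lower number from compound 1 to compound 2 (0.30 log units; within the scatter). Compound 3 `CCCCCCCCCCCCCCCCCCNC(=O)[C@@H](NC(=O)c1ccco1)[C@@H](C)O` differs from compound 1 by butyl in place of hydrogen on a saturated chain carbon, ten or more bonds along the chain from an amide-type nitrogen; in this assay compound 3 gives 13400 nM, and a 9.5-fold lower number from compound 1 to compound 3 (0.98 log units; beyond the scatter). Compound 3 thus stands lowest among the three measured numbers, with compound 2 and compound 1 above it by steps beyond the scatter.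

Compound 4 `CCCCCCCCCCCCCCCCCCNC(=O)[C@@H](NC(=O)c1cccs1)[C@@H](C)O` is not yet measured. It differs from compound 3 by thiophen-2-yl in place of furan-2-yl on a carbonyl carbon. This is the same kind of change as that from compound 1 to compound 2, made here on the core of compound 3 instead of the core of compound 1; the two cores differ by butyl in place of hydrogen on a saturated chain carbon, ten or more bonds along the chain from an amide-type nitrogen. Among the compounds with values here, the change occurs twice in the set and has only one measured instance, the step of a 2.0-fold lower number from compound 1 to compound 2 (0.30 log units; within the scatter), which lies within the scatter.

For compound 4 the step is therefore expected to be of similar small size, a 1.7-fold lower number from compound 3 to compound 4 (0.22 log units; within the scatter), resting on the step of a 2.0-fold lower number from compound 1 to compound 2 (0.30 log units; within the scatter) and on the value of compound 3, 13400 nM. Compound 4 is accordingly estimated at 8000 nM, with a plausible span from 3000 nM to 22000 nM.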

Compound 4, half-maximal inhibitory concentration: 117000 nM
Estimate against measurement, compound 4: 15-fold (1.17 log units) below; the measured number lies above the stated range.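

On the octadecyl core, thiophen-2-yl in place of furan-2-yl gives an 8.7-fold higher number from compound 3 to compound 4 (0.94 log units; beyond the scatter) in this assay, so the small step seen on the tetradecyl core does not carry over to this core: the same change on two cores in this assay, a 2.0-fold lower number (0.30 log units; within the scatter) from compound 1 to compound 2 and an 8.7-fold higher number (0.94 log units; beyond the scatter) from compound 3 to compound 4, 18-fold (1.25 log units) apart, beyond the scatter of two such steps. The chain change also depends on the group on the carbonyl carbon, since on the thiophen-2-yl side it gives only a 1.9-fold higher number from compound 2 to compound 4 (0.27 log units; within the scatter), which is much smaller than the step on the furan-2-yl side: the same change on two cores in this assay, a 9.5-fold lower number (0.98 log units; beyond the scatter) from compound 1 to compound 3 and a 1.9-fold higher number (0.27 log units; within the scatter) from compound 2 to compound 4, 18-fold (1.25 log units) apart, beyond the scatter of two such steps. The two changes are therefore not additive in these four compounds, and a step measured on one core is a poor guide to the same step on the other, but this rests on a single square of compounds and shows neither the reason for the dependence nor how either change behaves on any other core.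

The compounds shown leave open whether the furan-2-yl preference on the octadecyl core persists at intermediate or longer chains, such as hexadecyl or icosyl. They also leave open whether another group on the carbonyl carbon, such as phenyl or pyridin-3-yl, would follow compound 3 or compound 4 on the octadecyl core.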